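The compounds below may be only part of what the source reports. "The series", "measured", "known", "first", "only" and "open" are said of these compounds alone.

Measured so far in a functional assay on the whole organism for inhibition, with Mus musculus as the target; a lower number here means that less compound is needed, a higher number that more compound is needed for the effect:
compound 1 `CCCCNC(=O)Nc1cccc2c1CN(C)CC2c1ccccc1` gives about 40 mg/kg
compound 2 `CCCCNC(=O)Nc1cccc2c1CN(C)CC2c1ccc(Cl)cc1` gives 44 mg/kg
compound 3 `CCCCNC(=O)Nc1cccc2c1CN(C)CC2c1ccc(C)cc1` gives 40 mg/kg

Compound 2 stands level with the other two within the scatter (a 1.1-fold higher number from compound 1 to compound 2 (0.04 log units; within the scatter)) and (a 1.1-fold lower number from compound 2 to compound 3 (0.04 log units; within the scatter)), and the last pair agrees (no change at the digits printed from compound 1 to compound 3 (within the scatter)). Compound 4 `CCOC(=O)Nc1cccc2c1CN(C)CC2c1ccc(Cl)cc1` keeps the chloro and carries ethoxy in place of butylamino on a carbonyl carbon. The measured steps changed only an aromatic carbon's hydrogen, chloro or methyl, so none of them tests this change. No direction can therefore be given in this assay, and no step beyond the scatter is predicted. The expectation rests on compound 2 at 44 mg/kg with a wide margin. The expected step is small (no change at the digits printed from compound 2 to compound 4 (within the scatter)). For compound 4 the estimate is 44 mg/kg (expected range 15 mg/kg to 120 mg/kg).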

Compound 4, dose for half-maximal effect: 4.8 mg/kg
Compound 4: the middle estimate sits 9.2-fold (0.96 log units) above what was measured, and the stated range ends above it.
By their numbers in this assay, from the lowest: compound 4; then compounds 1, 3 and 2 (each within the scatter of the next).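

The earlier steps shown here changed only a group on the aromatic ring and stayed within the scatter in this assay, but the carbonyl position does respond: a 9.2-fold lower number from compound 2 to compound 4 (0.96 log units; beyond the scatter) comes with ethoxy in place of butylamino. This single swap both shortens the chain and replaces nitrogen with oxygen, so the step cannot be assigned to either change alone. No measurement at hand explains the step.

Still open, as far as these compounds go, is which of the two changes matters. Butoxy or ethylamino on the same carbonyl carbon would separate them.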